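The source may report more compounds than this note shows. Statements on the series, on what has been measured and on what is new or still open speak of the compounds shown alone.

Three compounds were tested in a functional assay on the whole organism for antagonist activity, with Rattus norvegicus as the target; on this read-out higher numbers stand for an effect only at larger amounts of compound and lower numbers for an effect already at smaller amounts. Compound 1 `c1ccc2c(c1)CC(CCN1CCN(c3cccc4c3OCCO4)CC1)C2` gives 0.27 mg/kg. Compound 2 `c1ccc2c(c1)CC(CCCN1CCN(c3cccc4c3OCCO4)CC1)C2` shares much of its build with compound 1, but how the two cores differ is not broken down here; in this assay compound 2 gives 0.47 mg/kg. Compound 3 `Clc1cccc2c1CC2CCN1CCN(c2cccc3c2OCCO3)CC1` gives 1.13 mg/kg.

Compound 3 arises from compound 1 by one change, (a group of 9 heavy atoms (8 carbon, 1 chlorine; one four-membered non-aromatic ring of carbon only, one six-membered aromatic ring of carbon only) in place of a group of 9 heavy atoms (9 carbon; one five-membered non-aromatic ring of carbon only, one six-membered aromatic ring of carbon only), on a saturated chain carbon, two bonds along the chain from an amine nitrogen in a ring), and that change made a step of a 4.2-fold higher number from compound 1 to compound 3 (0.62 log units; beyond the scatter).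

Compound 4 `Clc1cccc2c1CC2CCCN1CCN(c2cccc3c2OCCO3)CC1` is not yet measured. It arises from compound 2 by a group of 9 heavy atoms (8 carbon, 1 chlorine; one four-membered non-aromatic ring of carbon only, one six-membered aromatic ring of carbon only) in place of a group of 9 heavy atoms (9 carbon; one five-membered non-aromatic ring of carbon only, one six-membered aromatic ring of carbon only), on a saturated chain carbon, three bonds along the chain from an amine nitrogen in a ring. Among the compounds with values here, this is the same kind of change as the one from compound 1 to compound 3, though the place differs: in compound 1 it sits two bonds along the chain from the amine nitrogen in a ring, in compound 2 three bonds along.

For compound 4 a step of about a 3.8-fold higher number from compound 2 to compound 4 (0.58 log units; beyond the scatter) is expected, because the same kind of change gave a 4.2-fold higher number from compound 1 to compound 3 (0.62 log units; beyond the scatter). Compound 4 is therefore estimated at 1.8 mg/kg, with a likely span from 0.8 mg/kg to 4 mg/kg.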

Compound 4, dose for 50% inhibition: 3.09 mg/kg
For compound 4 the middle estimate is 1.7-fold (0.23 log units) below the measured one; measured number inside the range.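

In this assay, replacing the 2,3-dihydro-1H-inden-2-yl group with the chlorine-bearing group that has a four-membered ring, three bonds along the chain from an amine nitrogen in a ring, gave a 6.6-fold higher number from compound 2 to compound 4 (0.82 log units; beyond the scatter), so a larger dose was needed for the effect. Set beside the earlier step, the change went the same way on both cores, and the two step sizes cannot be told apart: the same change on two cores in this assay, a 4.2-fold higher number (0.62 log units; beyond the scatter) from compound 1 to compound 3 and a 6.6-fold higher number (0.82 log units; beyond the scatter) from compound 2 to compound 4, 1.6-fold (0.20 log units) apart, within the scatter of two such steps

Within the data shown here, this supports carrying the change between these two cores in this one read-out, but with only one pair per core, it does not show that the change would behave the same way on other cores, and it does not explain the rise.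

From the compounds shown here alone, the chlorine and the four-membered ring enter together, so it remains open which of them matters; a four-membered ring with no chlorine, or with fluorine or a methyl group in its place, would separate the two. Going by these compounds, how the same change behaves on a longer chain also remains open.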